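The source may hold more compounds than are shown below. What is called first, only, known or untested is meant among the compounds shown, and "the series" means these compounds.

Measured so far:
compound 1 `O=C(CN1CCC(c2ccccn2)CC1)Nc1c(Cl)cc(Cl)cc1Cl`: 45%
compound 2 `O=C(CN1CCC(c2cccc[n+]2[O-])CC1)Nc1ccc(F)cc1F`: 74%

In a functional assay on HEK293 cells for agonist activity at D(4) dopamine receptor (Homo sapiens), read by FLIPR (a higher number here means a larger maximal response, a lower number a smaller maximal response), compound 2 gives 74%, the higher of the two numbers; compound 1 gives 45%, a gap beyond the scatter. Compound 3 `CSc1cccc(NC(=O)CN2CCC(c3cccc[n+]3[O-])CC2)c1` differs from compound 2 by 3-(methylsulfanyl)phenyl in place of 2,4-difluorophenyl on an amide-type nitrogen. Among the compounds with values here, no measured pair shares this change, so its size is unknown, and the two measured compounds differ in more than one place. The expected step is a number 12 percentage points lower from compound 2 to compound 3 (beyond the scatter), a modest fall, roughly at the edge of the scatter. For compound 3 the estimate is 62%, with a range of 38% to 86%.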

Compound 3, largest response reached (reported as efficacy), in percent of the reference or control that the assay uses: 56%
Beside the measured number, compound 3's estimate is 6 percentage points above it; measured number inside the range.
By their numbers in this assay, from the lowest: compound 1; then compound 3; then compound 2.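

With the rest of the structure held constant, the group on the amide-type nitrogen alters the response in this assay: 3-(methylsulfanyl)phenyl in place of 2,4-difluorophenyl gives a number 18 percentage points lower from compound 2 to compound 3 (beyond the scatter), a modest step. Within the data shown here, this is the first change that can be read at a single place, and compound 3 still gives 56%. Nothing available accounts for the step.

This one swap does not separate the loss of the two fluorines from the arrival of methylsulfanyl. Plain phenyl or 3-methoxyphenyl on the same nitrogen would help to tell these apart.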